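From a ring group to carbamoylmethyl: compound 3 to compound 4

The source may report more compounds than this note shows. Statements on the series, on what has been measured and on what is new or still open speak of the compounds shown alone.

Three compounds share one core and differ in a single group. In a physicochemical assay for solubility, in phosphate buffer, measured as kinetic solubility (a higher number here means a more soluble compound, a lower number a less soluble compound), compound 1 `CC(C)C(c1ccc(-c2ccc3cccc(F)c3c2)[nH]c1=O)N1CCN/C1=N\C#N` gives 25200 nM, compound 2 `CC(C)C(Nc1nccs1)c1ccc(-c2ccc3cccc(F)c3c2)[nH]c1=O` gives 16100 nM, and compound 3 `CC(C)C(c1noc(=O)[nH]1)c1ccc(-c2ccc3cccc(F)c3c2)[nH]c1=O` gives 32500 nM. On these numbers, compound 3 cannot be told apart from compound 1 and stands only modestly clear of compound 2. The two steps that show this are a 1.3-fold higher number from compound 1 to compound 3 (0.11 log units; within the scatter) and a 2.0-fold higher number from compound 2 to compound 3 (0.31 log units; beyond the scatter).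

Compound 4 `CC(C)C(CC(N)=O)c1ccc(-c2ccc3cccc(F)c3c2)[nH]c1=O` changes that same group: a group of 4 heavy atoms (2 carbon, 1 nitrogen, 1 oxygen; no ring) in place of a group of 6 heavy atoms (2 carbon, 2 nitrogen, 2 oxygen; one five-membered aromatic ring with 3 hetero atoms), on a saturated chain carbon bound to an aromatic carbon and a saturated chain carbon. All three measured steps exchange a group at this place, and the remaining one is a 1.6-fold lower number from compound 1 to compound 2 (0.19 log units; within the scatter). None of them goes past a modest size, yet each involves two ring groups, and no open-chain group has been measured here, so the guide is loose. In this assay no step beyond the scatter is therefore expected. The estimated step is a 1.3-fold lower number from compound 3 to compound 4 (0.11 log units; within the scatter). Compound 4 is expected to give about 25000 nM, within an estimated range of 11000 nM to 55000 nM.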

Compound 4, solubility: 5600 nM
Estimate against measurement, compound 4: 4.5-fold (0.65 log units) above; the whole stated range lies above it.
By their numbers in this assay, from the lowest: compound 4; then compounds 2, 1 and 3 (each within the scatter of the next, the first and the last beyond it).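

Among these compounds, at this saturated chain carbon bound to an aromatic carbon and a saturated chain carbon, the measurement in this assay now includes carbamoylmethyl, an open-chain group, where the earlier compounds carried ring groups. The exchange gives a 5.8-fold lower number from compound 3 to compound 4 (0.76 log units; beyond the scatter) and a 4.5-fold lower number from compound 1 to compound 4 (0.65 log units; beyond the scatter) and also a 2.9-fold lower number from compound 2 to compound 4 (0.46 log units; beyond the scatter) as its three steps, all beyond the scatter, so compound 4 has the lowest number of the four and the three ring groups did not reveal how far the number can fall at this position. The data shown offer no measured explanation for this drop.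

One open-chain group cannot show whether the lack of a ring or the identity of carbamoylmethyl matters here. A carboxylic acid, an amine or a longer chain ending in the same amide at this carbon could help separate those two readings.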